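This account rests on a few compounds, and the source may have more. Where it says the series, first, only, none or still open, it means among the compounds named here.

Within the data shown here, compound 2 `CCCNCc1nc(Nc2nc(C)nc3c2c(C)nn3-c2ccc(OC)cc2C)no1` holds the lower of the two numbers measured so far. In a functional assay on CHO cells for antagonist activity at corticotropin-releasing factor receptor 1 (Homo sapiens), read by cAMP accumulation (on this read-out lower numbers stand for stronger inhibition and higher numbers for weaker inhibition), compound 2 gives 124 nM. Among the measured compounds shown here, its only measured neighbour, compound 1 `CCCNCc1nnc(Nc2nc(C)nc3c2c(C)nn3-c2ccc(OC)cc2C)o1`, differs from it solely in the five-membered ring carried on the nitrogen on the aromatic ring of the shared core; in this assay compound 1 gives 996 nM. That single step, an 8.0-fold lower number from compound 1 to compound 2 (0.90 log units; beyond the scatter), shows that exchanging one oxadiazole isomer for the other shifts the number well beyond the scatter.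

Compound 3 `CCCNCc1nccn1Nc1nc(C)nc2c1c(C)nn2-c1ccc(OC)cc1C` has not yet been measured in this assay. It differs from compound 2 by 2-((propylamino)methyl)-1H-imidazol-1-yl in place of 5-((propylamino)methyl)-1,2,4-oxadiazol-3-yl on a nitrogen on an aromatic ring. For the measured compounds named here, the step from compound 1 to compound 2 is the only measured one that bears on this change, and it concerned a swap between two oxadiazoles; no measured pair shows an oxadiazole giving way to an imidazole, so the direction is uncertain. Because an 8.0-fold lower number from compound 1 to compound 2 (0.90 log units; beyond the scatter) already showed that a change of ring moves the number clearly, and compound 2 sits at the low end, a rise is the more likely outcome, expected as a 3.2-fold higher number from compound 2 to compound 3 (0.51 log units; beyond the scatter). Compound 3 is therefore estimated at 400 nM, with a range from 80 nM to 2000 nM.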

Compound 3, inhibition constant: 400 nM
Compound 3: the middle estimate sits on the measured number at the digits printed; the measured number falls inside the stated range.
By their numbers in this assay, from the lowest: compound 2; then compound 3; then compound 1.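

In this assay, the position on the nitrogen on an aromatic ring now has a third five-membered ring, and the imidazole of compound 3 falls between the two oxadiazoles rather than beyond either: a 3.2-fold higher number from compound 2 to compound 3 (0.51 log units; beyond the scatter), and a 2.5-fold lower number from compound 1 to compound 3 (0.40 log units; beyond the scatter). Both steps lie beyond the scatter, so this position separates all three rings, and an oxadiazole is not required for a number below that of compound 1, though the 1,2,4-oxadiazole of compound 2 remains the lowest of the three. The order also does not follow the count of ring hetero atoms alone, as the imidazole, with fewer of them, sits between two oxadiazoles that differ from each other. No evidence on hand accounts for this order of the three rings.

Still open, as far as these compounds go, is how a 1,2,4-triazole or a pyrazole carrying the same side chain would rank at this position. Also open, from the compounds shown here alone, is whether the order of the rings would hold if the propylamino group gave way to a longer chain, such as butylamino, or to a cyclic amine such as morpholine.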